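The source may report more compounds than this note shows. Statements on the series, on what has been measured and on what is new or still open speak of the compounds shown alone.

Compound 1 `COc1ccc(-c2cc(-c3ccc(S(=O)(=O)N(C)C)cc3)cnc2N)cn1` — 6.3 ug/mL
Compound 2 `COc1ccc(-c2cc(-c3ccc(S(=O)(=O)NC4CC4)cc3)cnc2N)cn1` — 6.3 ug/mL
Compound 3 `COc1ccc(-c2cc(-c3ccc(NS(C)(=O)=O)cc3)cnc2N)cn1` — 25 ug/mL

In a physicochemical assay for solubility, read by nephelometry, in phosphate buffer, measured as kinetic solubility, at pH 6.5 (on this read-out higher numbers stand for higher solubility and lower numbers for lower solubility), compound 3 gives 25 ug/mL, the highest of the three values; the steps up to it are a 4.0-fold higher number from compound 1 to compound 3 (0.60 log units; beyond the scatter) and a 4.0-fold higher number from compound 2 to compound 3 (0.60 log units; beyond the scatter), both beyond the scatter, whereas no change at the digits printed from compound 1 to compound 2 (within the scatter). Compound 4 `COc1ccc(-c2cc(-c3ccc(-n4cccn4)cc3)cnc2N)cn1` differs from compound 3 by 1H-pyrazol-1-yl in place of methanesulfonamido on an aromatic carbon. Among the measured compounds shown here, both measured steps that reach compound 3 exchange one sulfonyl-containing group for another, and no measured step involves a pyrazole, so none bears directly on this change. With the donor of the methanesulfonamido gone and an aromatic ring entering, the expected step is a 3.1-fold lower number from compound 3 to compound 4 (0.49 log units; beyond the scatter), a modest fall rather than a rise. Compound 4 is thus estimated at 8 ug/mL in this assay, with a range of 2.5 ug/mL to 25 ug/mL.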

Compound 4, solubility: 3.1 ug/mL
Compound 4: middle estimate off by 2.6-fold (0.41 log units), on the high side, and the stated range covers the measured number.
By their numbers in this assay, from the lowest: compound 4; then compounds 1 and 2 (each within the scatter of the next); then compound 3.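

In this assay this aromatic carbon now shows a fall as well as a rise: 1H-pyrazol-1-yl in place of methanesulfonamido gives an 8.1-fold lower number from compound 3 to compound 4 (0.91 log units; beyond the scatter) at this position. The pyrazole also stands under both sulfamoyl groups, with a 2.0-fold lower number from compound 2 to compound 4 (0.31 log units; beyond the scatter) and a 2.0-fold lower number from compound 1 to compound 4 (0.31 log units; beyond the scatter) making compound 4 the lowest of the four. Nothing shown gives a reason for these steps.

The compounds shown leave open whether the fall follows from the loss of the methanesulfonamido donor or from the entering ring, which an N-methylated methanesulfonamido could help separate. From the compounds shown here alone, how a morpholine or a carboxylic acid would read on this carbon also remains open.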